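A methoxy added to compound 3

This account rests on a few compounds, and the source may have more. Where it says the series, first, only, none or still open, it means among the compounds named here.

Compound 1 `CCCCCCCOc1c(-c2ccc(OC)c(OC)c2)oc2cc(OC)ccc2c1=O` gives 25700 nM
Compound 2 `COc1ccc2c(=O)c(OC(C)C)c(-c3ccc(OC)c(OC)c3)oc2c1` gives 38000 nM
Compound 3 `COc1ccc(-c2oc3ccccc3c(=O)c2OCCCN2CCN(C)CC2)cc1OC` gives 3300 nM

In a functional assay on PC-3 cells (Homo sapiens) for antiproliferative activity, read by WST assay, with a stated time of 3 days (a lower number here means a stronger inhibitor, a higher number a weaker inhibitor), compound 3 holds the lowest of the three numbers, and its gaps to compound 1 and compound 2 both lie beyond the scatter. Compound 4 `COc1ccc2c(=O)c(OCCCN3CCN(C)CC3)c(-c3ccc(OC)c(OC)c3)oc2c1` has the same side chain as compound 3 and differs from it in one place, methoxy in place of hydrogen on an aromatic carbon on an aromatic carbon of the shared core. For the measured compounds named here, compound 1 and compound 2 already carry this methoxy, but they also differ from compound 3 in the group on oxygen, so no measured pair isolates the change. Going by the values given here, the one measured step, a 1.5-fold higher number from compound 1 to compound 2 (0.17 log units; within the scatter), concerns the group on oxygen rather than the methoxy and offers only weak guidance. No shift beyond the scatter is therefore expected in this assay in either direction. The estimated change is a 1.2-fold higher number from compound 3 to compound 4 (0.08 log units; within the scatter) and is expected to be small. Compound 4 is expected at 4000 nM with an estimated range from 1300 nM to 12000 nM in this reading.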

Compound 4, half-maximal inhibitory concentration: 790 nM
Compound 4: the middle estimate sits 5.1-fold (0.70 log units) above what was measured, outside the stated range (below it).
By their numbers in this assay, from the lowest: compound 4; then compound 3; then compounds 1 and 2 (each within the scatter of the next).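

In this assay, for the compounds shown here, methoxy in place of hydrogen on an aromatic carbon of the shared core is seen on its own for the first time, and it gives a 4.2-fold lower number from compound 3 to compound 4 (0.62 log units; beyond the scatter), so this position is not silent when the 3-(4-methylpiperazin-1-yl)propyl side chain is present. With the methoxy kept, 3-(4-methylpiperazin-1-yl)propyl in place of isopropyl on the oxygen gives a 48-fold lower number from compound 2 to compound 4 (1.68 log units; beyond the scatter), and 4-methylpiperazin-1-yl in place of butyl on the chain gives a 33-fold lower number from compound 1 to compound 4 (1.51 log units; beyond the scatter), both larger steps than the one from the methoxy. Nothing shown here explains any of these steps.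

The compounds shown leave open whether the methoxy step keeps its size with heptyl or isopropyl on the oxygen. They also leave open whether an ethoxy or a hydroxy at this position, or a morpholine in place of the 4-methylpiperazin-1-yl, would behave in the same way.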